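Replacing 3,5-difluorophenyl with 3-methylthiophen-2-yl in compound 3

The source may hold more compounds than are shown below. What is called first, only, known or untested is meant among the compounds shown, and "the series" means these compounds.

Measured in a functional assay on MCF7 cells (Homo sapiens) for cytotoxicity (on this read-out lower numbers stand for stronger inhibition and higher numbers for weaker inhibition), so far:
compound 1 `C=C/C=C\[C@H](C)[C@H](OC(N)=O)[C@@H](C)[C@H](O)[C@@H](C)C/C(C)=C\[C@H](C)[C@@H](O)[C@@H](C)/C=C\CCc1ccc(C)c(F)c1` gives 1000 nM
compound 2 `C=C/C=C\[C@H](C)[C@H](OC(N)=O)[C@@H](C)[C@H](O)[C@@H](C)C/C(C)=C\[C@H](C)[C@@H](O)[C@@H](C)/C=C\CCc1ccc(C)c(O)c1` gives 770 nM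
compound 3 `C=C/C=C\[C@H](C)[C@H](OC(N)=O)[C@@H](C)[C@H](O)[C@@H](C)C/C(C)=C\[C@H](C)[C@@H](O)[C@@H](C)/C=C\CCc1cc(F)cc(F)c1` gives 600 nM

These three values lie within the usual scatter of one another, which places compound 3 level with compound 1 and compound 2. The next compound to be tested is compound 4 `C=C/C=C\[C@H](C)[C@H](OC(N)=O)[C@@H](C)[C@H](O)[C@@H](C)C/C(C)=C\[C@H](C)[C@@H](O)[C@@H](C)/C=C\CCc1sccc1C`, and its difference from compound 3 is 3-methylthiophen-2-yl in place of 3,5-difluorophenyl on a saturated chain carbon, two bonds along the chain from a double-bonded chain carbon. In words, 3-methylthiophen-2-yl stands in place of 3,5-difluorophenyl on a saturated chain carbon, two bonds along the chain from a double-bonded chain carbon.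

Two measured steps replace the aromatic group at this same place: a 1.7-fold lower number from compound 1 to compound 3 (0.22 log units; within the scatter) and a 1.3-fold lower number from compound 2 to compound 3 (0.11 log units; within the scatter). Both stay within the scatter. Neither involves a five-membered aromatic ring, which makes any forecast for compound 4 uncertain, and the expected range is kept wide. The expected step is a 1.3-fold higher number from compound 3 to compound 4 (0.12 log units; within the scatter), no larger than the scatter. For compound 4 the estimated value is 800 nM, within an expected range of 300 nM to 2000 nM.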

Compound 4, half-maximal inhibitory concentration: 370 nM
Compound 4: the middle estimate sits 2.2-fold (0.33 log units) above what was measured, within the range that was stated.
By their numbers in this assay, from the lowest: compounds 4, 3, 2 and 1 (each within the scatter of the next, the first and the last beyond it).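

In this assay, the saturated chain carbon, two bonds along the chain from a double-bonded chain carbon, also tolerates a five-membered aromatic ring with a sulfur atom, since 3-methylthiophen-2-yl gives (a 1.6-fold lower number from compound 3 to compound 4 (0.21 log units; within the scatter)) when it replaces 3,5-difluorophenyl. Among the compounds shown here, the same group also gives the first steps at this place that lie beyond the scatter, though both are modest: (a 2.1-fold lower number from compound 2 to compound 4 (0.32 log units; beyond the scatter)) and (a 2.7-fold lower number from compound 1 to compound 4 (0.43 log units; beyond the scatter)). The ring here therefore need not be a six-membered ring of carbon only, but compound 4 remains level with compound 3, so the gain holds only against compound 1 and compound 2.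

Nothing shown explains these differences. Going by these compounds, it also remains open whether a furan-2-yl or pyridin-3-yl ring, or an amine on the thiophene ring, would be tolerated at this place.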